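A few compounds are considered here, and "the series" means these few. Any claim that something is new, unique, unknown or untested is made for them only; others in the source may bear on it.

Compound 1 `CCOC(=O)N1CCC(N(Cc2cccc([N+](=O)[O-])c2)C(=O)N(C)C)CC1`: 26000 nM in a functional assay on K562 cells (Homo sapiens) for antiproliferative activity, read by MTT assay, with a stated time of 48 h; on this read-out higher numbers stand for weaker inhibition and lower numbers for stronger inhibition.
Compound 2 `CCOC(=O)N1CCC(N(Cc2cc([N+](=O)[O-])ccc2O)C(=O)N(C)C)CC1`: 38400 nM in this assay.

Going by the values given here, compound 2 holds the higher of the two numbers in this assay; its only neighbour is compound 1, and the step of a 1.5-fold higher number from compound 1 to compound 2 (0.17 log units; within the scatter) lies within the scatter. Compound 3 `CCOC(=O)N1CCC(N(Cc2cc(Br)ccc2O)C(=O)N(C)C)CC1` differs from compound 2 by bromo in place of nitro on an aromatic carbon. Among the compounds with values here, no measured step touches this group; the single step at hand, a 1.5-fold higher number from compound 1 to compound 2 (0.17 log units; within the scatter), concerns the hydroxy group at another place and was small. No step beyond the scatter is therefore expected: a 1.0-fold lower number from compound 2 to compound 3 (0.00 log units; within the scatter). Compound 3 is estimated at 38000 nM, within a range from 12000 nM to 120000 nM.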

Compound 3, half-maximal inhibitory concentration: 41800 nM
Estimate against measurement, compound 3: 1.1-fold (0.04 log units) below, within the range that was stated.
By their numbers in this assay, from the lowest: compounds 1, 2 and 3 (each within the scatter of the next).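

At the place para to a hydroxy group, bromo in place of nitro gives a step within the scatter in this assay (a 1.1-fold higher number from compound 2 to compound 3 (0.04 log units; within the scatter)), so this exchange of a nitro group for a single bromine atom does not separate the two compounds. The larger change to 5-bromo-2-hydroxyphenyl in place of 3-nitrophenyl also stays within the scatter (a 1.6-fold higher number from compound 1 to compound 3 (0.21 log units; within the scatter)). Nothing available explains this result.

The compounds shown leave open whether an amine or a carboxylic acid at this place would give a step beyond the scatter.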